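Adding a second chloro to compound 2

The compounds below may be only part of what the source reports. "The series", "measured", "known", "first", "only" and "open" are said of these compounds alone.

In a functional assay on MDA-MB-231 cells (Homo sapiens) for antiproliferative activity, with a stated time of 72 h (on this read-out higher numbers stand for weaker inhibition and lower numbers for stronger inhibition), compound 1 `Cn1c(N2N=C(c3ccccc3)CC2c2ccccc2)nc(-c2ccccc2)c(C#N)c1=O` gives 3990 nM, compound 2 `Cn1c(N2N=C(c3ccc(Cl)cc3)CC2c2ccccc2)nc(-c2ccccc2)c(C#N)c1=O` gives 10600 nM and compound 3 `COc1ccc(C2CC(c3ccc(Cl)cc3)=NN2c2nc(-c3ccccc3)c(C#N)c(=O)n2C)cc1` gives 11100 nM. Compound 2 thus lies within the scatter of compound 3, and both carry higher numbers than compound 1. Compound 4 `Cn1c(N2N=C(c3ccc(Cl)cc3)CC2c2ccccc2)nc(-c2ccc(Cl)cc2)c(C#N)c1=O` differs from compound 2 by chloro in place of hydrogen on an aromatic carbon, phenyl to 4-chlorophenyl. Going by the values given here, the nearest precedent is the same kind of change elsewhere in the molecule, a 2.7-fold higher number from compound 1 to compound 2 (0.42 log units; beyond the scatter), a modest step beyond the scatter. The methoxy change, a 1.0-fold higher number from compound 2 to compound 3 (0.02 log units; within the scatter), stays within the scatter. A modest upward move is therefore expected, a 1.4-fold higher number from compound 2 to compound 4 (0.15 log units; within the scatter). For compound 4 the estimated value is 15000 nM, with an expected range of 7000 nM to 30000 nM.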

Compound 4, half-maximal inhibitory concentration: 12400 nM
Compound 4: middle estimate off by 1.2-fold (0.08 log units), on the high side, within the range that was stated.
By their numbers in this assay, from the lowest: compound 1; then compounds 2, 3 and 4 (each within the scatter of the next).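

In this assay, phenyl to 4-chlorophenyl at this position gives a 1.2-fold higher number from compound 2 to compound 4 (0.07 log units; within the scatter), so with compound 2 as the background this position takes a chloro without a readable change. The same replacement on another ring gave a 2.7-fold higher number from compound 1 to compound 2 (0.42 log units; beyond the scatter), so a chloro does not read the same at the two places. No measurement here bears on the reason for this difference. Going by these compounds, it remains open whether the step holds when the other ring carries hydrogen, as in compound 1, and whether an amine or a carboxylic acid in place of the chloro would move the number beyond the scatter.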